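Triazole N-aryl swap in the prenylated chromanone oxime ethers

The source may hold more compounds than are shown below. What is called first, only, known or untested is meant among the compounds shown, and "the series" means these compounds.

Three compounds of this series have numbers in a functional assay on A549 cells (Homo sapiens) for inhibition, read by sulforhodamine B assay, with a stated time of 48 h, tested at 50 uM; a lower number here means less inhibition of growth, a higher number more inhibition of growth at the concentration tested. Compound 1 `CCOc1ccc([C@@H]2CC(=O)c3cc(CC=C(C)C)c(OC)cc3O2)cc1` gives 37%, compound 2 `COc1ccc([C@@H]2C/C(=N/OCc3cn(-c4ccc(C(=O)c5ccccc5)cc4)nn3)c3cc(CC=C(C)C)c(OC)cc3O2)cc1` gives 34%, and compound 3 `COc1ccc([C@@H]2C/C(=N/OCc3cn(-c4cccc(CO)c4)nn3)c3cc(CC=C(C)C)c(OC)cc3O2)cc1` gives 43%. Compound 3 stands highest of the three numbers, but the gaps to compound 1 and to compound 2 both lie within the usual scatter, so the three sit together. Compound 4 `COc1ccc([C@@H]2C/C(=N/OCc3cn(-c4ccc(C#N)cc4)nn3)c3cc(CC=C(C)C)c(OC)cc3O2)cc1` is not yet measured; it differs from compound 3 by 4-cyanophenyl in place of 3-(hydroxymethyl)phenyl on an aromatic nitrogen. Among the compounds with values here, no pair of measured compounds differing in one place is available, so nothing points to a shift beyond the scatter. The step of a number 5 percentage points lower from compound 3 to compound 4 (within the scatter) is expected to stay within it. Compound 4 is therefore estimated at 38%, with a range from 22% to 54%.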

Compound 4, percent growth inhibition at one concentration: 42%
Compound 4: middle estimate off by 4 percentage points, on the low side, within the range that was stated.
By their numbers in this assay, from the lowest: compounds 2, 1, 4 and 3 (each within the scatter of the next).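

In this assay, 4-cyanophenyl in place of 3-(hydroxymethyl)phenyl on an aromatic nitrogen gives a number 1 percentage points lower from compound 3 to compound 4 (within the scatter), so this exchange, which removes the hydrogen-bond donor of the leaving group, does not separate the two compounds. Cyano in place of benzoyl on an aromatic carbon gives a number 8 percentage points higher from compound 2 to compound 4 (within the scatter), so this change does not separate its pair either. No measurement is available to explain either result.

Open, on these data alone, is whether a primary amine or a carboxylic acid on this phenyl ring would give a step beyond the scatter. Also open, as far as these compounds go, is whether a longer alkyl chain in place of the phenyl ring would do so.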